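The source may hold more compounds than are shown below. What is called first, only, known or untested is meant among the compounds shown, and "the series" means these compounds.

Measured in a functional assay (Sphincter muscle) with Felis catus as the target; on this read-out lower numbers stand for an effect already at smaller amounts and higher numbers for an effect only at larger amounts of compound:
- Compound 1 `O=C(O)CCC/C=C\C[C@@H]1[C@@H](/C=C/C(O)CCc2cccc(Br)c2)[C@H](O)C[C@@H]1O`: 33 nM; 4.9 nM (2 entries)
- Compound 2 `Cc1cccc(CCC(O)/C=C/[C@@H]2[C@@H](C/C=C\CCCC(=O)O)[C@@H](O)C[C@H]2O)c1`: 4.3 nM

In this assay, compound 2 has one number, 4.3 nM, and a further entry without a single number. Its position is therefore less firmly fixed than that one number suggests. Repeat readings can also lie far apart, as compound 1 shows: the several entries of compound 1 in this assay, 33 nM; 4.9 nM (2 entries).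

Compound 3 `Cc1ccc(CCC(O)/C=C/[C@@H]2[C@@H](C/C=C\CCCC(=O)O)[C@@H](O)C[C@H]2O)cc1` has not yet been measured. It carries 4-methylphenyl in place of 3-methylphenyl on a saturated chain carbon, three bonds along the chain from a double-bonded chain carbon and an oxygen on a saturated carbon. Among the compounds with values here, no measured step shows the effect of this change. In this assay, a modest move toward a higher number is expected, with the estimated step of a 2.3-fold higher number from compound 2 to compound 3 (0.37 log units; beyond the scatter). For compound 3 the expected value is 10 nM, with an estimated range of 3 nM to 40 nM.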

Compound 3, half-maximal effective concentration: 40 nM
Compound 3: middle estimate off by 4.0-fold (0.60 log units), on the low side; the measured number falls inside the stated range.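

Within the data shown here, until now no measured step had covered this position, and compound 3 provides the first: exchanging 3-methylphenyl for 4-methylphenyl on the saturated chain carbon gives, in this assay, a 9.3-fold higher number from compound 2 to compound 3 (0.97 log units; beyond the scatter). The two groups have the same heavy-atom count and the same aromatic ring, and neither has any hydrogen-bond donors or acceptors, so the read-out here responds to how the same atoms are joined, not to any difference in these counts. This single step still needs caution, since repeat readings in this assay can lie far apart: the several entries of compound 1 in this assay, 33 nM; 4.9 nM (2 entries)

The compounds shown leave open whether the higher number is specific to 4-methylphenyl or would also appear with 4-bromophenyl. They also do not show how an unsubstituted phenyl or a 2-methylphenyl would read at this place.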